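This account rests on a few compounds, and the source may have more. Where it says the series, first, only, none or still open, it means among the compounds named here.

Compound 1, `CCCCSc1nc(N)nc2c1ncn2/C=C1/CC1(CO)CO`, gives 89000 nM in an ADME assay on CCRF-HSB-2 cells (Homo sapiens) for cytotoxicity, with a stated time of 7 days; a lower number here means that less compound is tolerated, a higher number that more compound is tolerated.
Compound 2, `Nc1nc(NC2CC2)c2ncn(/C=C3/CC3(CO)CO)c2n1`, reaches only a limit of this assay, > 20000 nM.
Compound 3, `Nc1nc(OCC(F)(F)F)c2ncn(/C=C3/CC3(CO)CO)c2n1`, likewise shows only a limit, > 20000 nM.

Compound 2 therefore stands at the edge of what this assay can report: no number is known for it, only a limit, and compound 3 shares that position, as the limit of > 20000 nM in this assay, at which 2 of the 3 values shown sit, records. Only compound 1 carries a real number. Against this background the change from compound 2 to compound 4, `COCCOc1nc(N)nc2c1ncn2/C=C1/CC1(CO)CO`, is 2-methoxyethoxy in place of cyclopropylamino on an aromatic carbon. The cyclopropylamino group with its three-membered non-aromatic ring leaves, and a 2-methoxyethoxy chain with no ring and no hydrogen-bond donor enters.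

Among the measured compounds shown here, two measured steps touch on this change, but neither can be read: a step that the limit leaves unreadable from compound 1 to compound 2 and a step that the two limits leave unreadable from compound 2 to compound 3. Compound 3 shows that a group without a nitrogen on this carbon still sits at the limit. The expectation is thus that compound 4 also stays near the limit, with a step that the limit leaves unreadable from compound 2 to compound 4. Compound 4 is estimated at 30000 nM, within 10000 nM to 100000 nM.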

Compound 4, half-maximal cytotoxic concentration: > 20000 nM
Compound 4 was reported as a limit (the forecaster's own chance of this, stated with the estimate: 65%); the middle value is on the limit's open side.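

Compound 4 also gives only a limit in this assay, so its steps to compound 1, compound 2 and compound 3 cannot be read, and it joins compound 2 and compound 3 at: the limit of > 20000 nM in this assay, at which 3 of the 4 values shown sit.

Still open, on these data alone, is what real numbers compound 2, compound 3 and compound 4 would give, and how they would compare with compound 1 at 89000 nM.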